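From a Ring Amine to an Open Chain at One Position

The source may report more compounds than this note shows. Statements on the series, on what has been measured and on what is new or still open speak of the compounds shown alone.

Compound 1, `OC1CCN(c2ncnc3[nH]cc(-c4cccc(Cl)c4)c23)CC1`: 80 nM in an assay for inhibition of serine/threonine-protein kinase 4 (Homo sapiens), read by luminescence and ADP-Glo, in the presence of a further agent that is not named here; on this read-out lower numbers stand for stronger inhibition and higher numbers for weaker inhibition
Compound 2, `CC1(N)CCN(c2ncnc3[nH]cc(-c4cccc(Cl)c4)c23)CC1`: 163 nM in this assay

Within the data shown here, compound 2 carries the highest of the two numbers measured so far; its only neighbour is compound 1, and the one measured step, a 2.0-fold higher number from compound 1 to compound 2 (0.31 log units; beyond the scatter), was modest, a change at the same aromatic carbon in which 4-amino-4-methylpiperidin-1-yl replaced 4-hydroxypiperidin-1-yl.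

Compound 3, `CC(CO)CN(C)c1ncnc2[nH]cc(-c3cccc(Cl)c3)c12`, keeps the shared core and alters compound 2 at that same carbon: a group of 7 heavy atoms (5 carbon, 1 nitrogen, 1 oxygen; no ring) in place of a group of 8 heavy atoms (6 carbon, 2 nitrogen; one six-membered non-aromatic ring with 1 hetero atom), on an aromatic carbon

Among the measured compounds shown here, only the step from compound 1 to compound 2 bears on this change, since it is the sole measured alteration at this position, and it shifted the number modestly. For the measured compounds named here, no measured step opens a ring into a chain, so the expectation for compound 3 rests on that single comparison and on the fact that donor and acceptor counts are unchanged. A modest shift toward a higher number is expected, a 1.8-fold higher number from compound 2 to compound 3 (0.26 log units; within the scatter), though the range must stay wide. In this assay compound 3 is estimated at 300 nM, within 100 nM to 900 nM.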

Compound 3, half-maximal inhibitory concentration: 38 nM
For compound 3 the middle estimate is 7.9-fold (0.90 log units) above the measured one; measured number outside the range, below it.
By their numbers in this assay, from the lowest: compound 3; then compound 1; then compound 2.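

Placed on this aromatic carbon, the open chain of 7 heavy atoms gives the lowest number of the three in this assay, with a 4.3-fold lower number from compound 2 to compound 3 (0.63 log units; beyond the scatter) and a 2.1-fold lower number from compound 1 to compound 3 (0.32 log units; beyond the scatter), so among these compounds a six-membered non-aromatic ring is not needed here for stronger inhibition. The step from compound 1 is the more telling of the two: the group that leaves and the group that enters have the same count of heavy atoms, of the same elements, and differ in that one has a ring and the other has none, so the number can move without any change in those counts. Nothing measured here accounts for this shift in terms of the structures involved.

Still open, as far as these compounds go, is which part of the chain in compound 3 carries the result, the hydroxyl, the methyl branch or the methyl on the nitrogen, and whether an amine in place of that hydroxyl would give a similar number. Also open, from the compounds shown here alone, is how a longer chain would read in this assay, since a single acyclic group cannot show how far this trend extends.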